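The compounds below may be only part of what the source reports. "The series", "measured", "known", "first", "only" and "open" are said of these compounds alone.

Compound 1 `Cc1ccc(-c2cn(C[C@H]3c4c(ccc(O)c4C)[C@@H]4CC[C@@]5(C)C[C@]43CC5=O)nn2)cc1` carries a 4-methylphenyl group on a triazole that is joined through a short linker to its core. In a functional assay on A549 cells (Homo sapiens) for cytotoxicity, read by MTT assay, with a stated time of 4 days (a higher number here means a weaker inhibitor, a lower number a stronger inhibitor), compound 1 gives > 20000 nM, and this is a limit of the assay rather than a measured number. Compound 3 `C=C1C[C@]23C[C@@]1(O)CC[C@H]2c1ccc(O)c(C)c1[C@@H]3Cn1cc(-c2ccc(C)cc2)nn1` carries the same 4-methylphenyl group on a different core; the difference between the two cores is not broken down here. In this assay compound 3 gives > 20000 nM, again a limit. Compound 2 `C=C1C[C@]23C[C@@]1(O)CC[C@H]2c1ccc(O)c(C)c1[C@@H]3Cn1cc(-c2ccc(OC)cc2)nn1` differs from compound 3 by methoxy in place of methyl on an aromatic carbon. In this assay compound 2 gives > 20000 nM, also a limit. The step that the two limits leave unreadable from compound 3 to compound 2 therefore cannot be sized, because both of its ends sit at the limit of > 20000 nM in this assay, at which 3 of the 3 values shown sit.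

Compound 4 `COc1ccc(-c2cn(C[C@H]3c4c(ccc(O)c4C)[C@@H]4CC[C@@]5(C)C[C@]43CC5=O)nn2)cc1` has not been measured. It differs from compound 1 by methoxy in place of methyl on an aromatic carbon, which is the same change, at the same place, that leads from compound 3 to compound 2. Because every measured value here sits at the limit of > 20000 nM in this assay, at which 3 of the 3 values shown sit, this change has not been seen to move the number into the readable range on either core. For compound 4 the step that the limit leaves unreadable from compound 1 to compound 4 is expected to be small. Compound 4 is expected to give about 30000 nM in this assay, most likely again only as a limit, within a range from 12000 nM to 100000 nM.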

Compound 4, half-maximal inhibitory concentration: > 20000 nM
Compound 4 gave a limit, no number; the forecaster's own chance of this, stated with the estimate: 85%; the middle value is on the limit's open side.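

No step can be read from compound 1 to compound 4, because both compounds give only a limit of the assay and no actual number: the limit of > 20000 nM in this assay, at which 4 of the 4 values shown sit.

The compounds shown leave open whether going from 4-methylphenyl to 4-methoxyphenyl changes the cytotoxicity on either core, and what kind of compound in this series would give a readable number at all.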